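Benzyl to methyl on the shared core

A few compounds are considered here, and "the series" means these few. Any claim that something is new, unique, unknown or untested is made for them only; others in the source may bear on it.

Of the compounds shown here, two have been read so far in an ADME assay on HepG2 cells (Homo sapiens) for cytotoxicity, in the presence of a further agent that is not named here; a lower number here means a stronger inhibitor, a higher number a weaker inhibitor. Compound 1 `Cn1c(Cc2ccccc2C(F)(F)F)nc(C(=O)NCc2cccnc2)c(O)c1=O` gives > 100000 nM, which is a limit of the assay and not a number. Compound 2 `Cn1c(Cc2ccccc2)nc(C(=O)NCc2ccccc2)c(O)c1=O` gives > 100000 nM, again only a limit. The whole of the record is thus (the limit of > 100000 nM in this assay, at which 2 of the 2 values shown sit), and compound 2 stands there with no number of its own.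

Compound 3 `Cc1nc(C(=O)NCc2ccccc2)c(O)c(=O)n1C` differs from compound 2 in one place: hydrogen in place of phenyl on a saturated chain carbon bound to an aromatic carbon. Hydrogen comes in place of phenyl on a saturated chain carbon bound to an aromatic carbon, which, cut one bond further out, reads benzyl to methyl.

Among the measured compounds shown here, no measured step gauges this change, so the expectation rests on the two limits alone. In this assay the expected step is a number no higher from compound 2 to compound 3 (the limit leaves the size open), in neither direction beyond the usual scatter. A further report as a limit is the likeliest outcome. For compound 3 the estimated value is 100000 nM, with an expected range of 50000 nM to 200000 nM.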

Compound 3, half-maximal inhibitory concentration: > 100000 nM
Compound 3: no number, only a limit (the forecaster's own chance of this, stated with the estimate: 85%); the middle value sits exactly at the limit.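

In this assay compound 3 gives > 100000 nM, a limit of the assay and not a number. Among the compounds shown here, compound 2 also stands only at a limit, so no step between compound 2 and compound 3 can be read. The compounds shown leave open what size of effect, if any, benzyl to methyl has here: the limit of > 100000 nM in this assay, at which 3 of the 3 values shown sit.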